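Cinnamate glycolamide series: chloro to methoxy on anilide

A few compounds are considered here, and "the series" means these few. Any claim that something is new, unique, unknown or untested is made for them only; others in the source may bear on it.

Measured so far:
compound 1 `COc1ccc(/C=C/C(=O)OCC(=O)Nc2ccccc2)cc1OC`: > 200000 nM
compound 2 `COCOc1cc(/C=C/C(=O)OCC(=O)Nc2ccc(Cl)cc2)ccc1OCc1ccccc1`: > 200000 nM

In a functional assay on K562 cells (Homo sapiens) for cytotoxicity, read by MTT assay, with a stated time of 72 h (a lower number here means a stronger inhibitor, a higher number a weaker inhibitor), compound 1 gives > 200000 nM, which is a limit of the assay and not a number. In this assay compound 2 gives > 200000 nM; this too is a limit rather than a measured number. For the measured compounds named here, compound 2 thus stands at the limit together with the only other value known, as the limit of > 200000 nM in this assay, at which 2 of the 2 values shown sit, records, and no step between measured compounds can be drawn from the two of them.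

Compound 3 `COCOc1cc(/C=C/C(=O)OCC(=O)Nc2ccc(OC)cc2)ccc1OCc1ccccc1` is the next member to be tested, differing from compound 2 by methoxy in place of chloro on an aromatic carbon. Going by the values given here, with both known values sitting at the limit, there is no measured step of this kind to lean on, and the anilide change is the whole of what is known. The step expected from compound 2 to compound 3 in this assay is a number no higher from compound 2 to compound 3 (the limit leaves the size open), which is none beyond the scatter. Compound 3 is accordingly estimated at 200000 nM, with a range from 80000 nM to 500000 nM, and the most likely outcome is that this assay again reports only a limit for it.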

Compound 3, half-maximal inhibitory concentration: > 200000 nM
Compound 3 ended at the assay's limit (the forecaster's own chance of this, stated with the estimate: 85%); the middle value sits exactly at the limit.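

Compound 2 and compound 3 both reach only a limit in this assay, so the change from chloro to methoxy gives no readable step, and the same limit holds across the series shown: the limit of > 200000 nM in this assay, at which 3 of the 3 values shown sit.

The compounds shown leave open whether any change to the shared core gives a measured number in this assay, and how chloro and methoxy would compare there.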